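A few compounds are considered here, and "the series" means these few. Any claim that something is new, unique, unknown or untested is made for them only; others in the source may bear on it.

Measured so far:
compound 1 `O=C(C1CCC1)N1CC2CC(C1)N2`, 2900 nM in an assay on SH-EP1 cells for agonist activity at Neuronal acetylcholine receptor; alpha4/beta2 (Homo sapiens), read by FLIPR and calcium flux; on this read-out higher numbers stand for an effect only at larger amounts of compound and lower numbers for an effect already at smaller amounts
compound 2 `C[C@@H]1C[C@H]1C(=O)N1CC2CC(C1)N2`, 190 nM in this assay

Among the measured compounds shown here, compound 2 stands lowest of the two numbers in this assay; the single measured step, a 15-fold lower number from compound 1 to compound 2 (1.18 log units; beyond the scatter), concerns the group on the carbonyl carbon. Compound 3 `C[C@H]1C[C@@H]1C(=O)N1CC2CC(C1)N2` differs from compound 2 only in configuration: the two compounds have the same atoms and bonds; at least one stereo element is drawn with a configuration in one of them and without one in the other: 2 of 4 stereo elements differ; a stereocentre at a saturated ring carbon is drawn R in compound 2 and S in compound 3; a stereocentre at a saturated ring carbon is drawn R in compound 2 and S in compound 3. For the measured compounds named here, no measured step bears on an inversion of stereocentres, so the size of the step in this assay cannot be read from the data, and a change in either direction is possible. Compound 3 is expected to give 700 nM (range 150 nM to 4000 nM). The expected step is a 3.7-fold higher number from compound 2 to compound 3 (0.57 log units; beyond the scatter), set with wide bounds.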

Compound 3, half-maximal effective concentration: 9100 nM
Beside the measured number, compound 3's estimate is 13-fold (1.11 log units) below it, outside the stated range (above it).
By their numbers in this assay, from the lowest: compound 2; then compound 1; then compound 3.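

In this assay the 2-methylcyclopropyl group on the carbonyl carbon has no single effect: a change of configuration alone gives a 48-fold higher number from compound 2 to compound 3 (1.68 log units; beyond the scatter). Set against cyclobutyl, the same group can also end up worse, with a 3.1-fold higher number from compound 1 to compound 3 (0.50 log units; beyond the scatter), so the earlier drop in the number holds for the configuration of compound 2 only. This reading carries a caveat: the fact that one of compounds 2 and 3 is drawn with a defined configuration and the other without, at the place where they differ

Still open, going by these compounds, is whether an ethyl or a trifluoromethyl group in place of the methyl would keep the low number of compound 2, and whether either would show the same dependence on configuration.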